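Shrinking the Ring Amine on a Quinone-Like Core

The source may report more compounds than this note shows. Statements on the series, on what has been measured and on what is new or still open speak of the compounds shown alone.

Measured so far in a functional assay on MGC-803 cells (Homo sapiens) for inhibition, read by sulforhodamine B assay; a higher number here means a weaker inhibitor, a lower number a stronger inhibitor:
compound 1 `O=C1C(NC2CC2)=CC(=O)c2c1nc1n2[C@H]2OC[C@@H](O)[C@H]2OC1`: > 4000 nM
compound 2 `O=C1C(N2CCCCC2)=CC(=O)c2c1nc1n2[C@H]2OC[C@@H](O)[C@H]2OC1`: > 4000 nM
compound 3 `O=C1C=C(Nc2ccccc2)C(=O)c2c1nc1n2[C@H]2OC[C@@H](O)[C@H]2OC1`: 1730 nM.

Compound 1 gives > 4000 nM, which is a limit of this assay, not a number. For compound 2, the value of > 4000 nM is likewise a limit. Compound 3, with phenylamino on the shared core, gives a readable value of 1730 nM. Within the data shown here, compound 2 therefore stands at the limit, and its only neighbouring step, a step that the two limits leave unreadable from compound 1 to compound 2, cannot be sized because both ends are limits; the limit of > 4000 nM in this assay, at which 2 of the 3 values shown sit, marks where two of the three values sit.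

The compound not yet measured is compound 4 `O=C1C(N2CCCC2)=CC(=O)c2c1nc1n2[C@H]2OC[C@@H](O)[C@H]2OC1`. It differs from compound 2 as follows: pyrrolidin-1-yl in place of piperidin-1-yl on a double-bonded ring carbon. Among the measured compounds shown here, no measured step bears directly on this change. With compound 2 at the limit, the most likely outcome for compound 4 is again a limit, and the step that the limit leaves unreadable from compound 2 to compound 4 is expected to be small or unreadable. Compound 4 is estimated at 6000 nM, within 2000 nM to 20000 nM.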

Compound 4, half-maximal inhibitory concentration: > 16000 nM
Compound 4 ended at the assay's limit; the forecaster's own chance of this, stated with the estimate: 70%; at least 2.6-fold (0.42 log units) between middle value and limit.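

In this assay compound 4 gives > 16000 nM, which is a limit of the assay and not a number. Compound 1 and compound 2 also stand at limits, so neither step to compound 4 can be read. As far as these compounds go, how strongly these three compounds inhibit remains open.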